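Selenoether quinazoline series: removal of the benzyl group

A few compounds are considered here, and "the series" means these few. Any claim that something is new, unique, unknown or untested is made for them only; others in the source may bear on it.

Compound 1 `CCCCC[Se]c1nc(NCc2ccc(SC)cc2)c2ccccc2n1` gives > 100000 nM in a functional assay on HT-29 cells (Homo sapiens) for cytotoxicity, read by MTT assay, with a stated time of 72 h (on this read-out lower numbers stand for stronger inhibition of growth and higher numbers for weaker inhibition of growth), which is a limit of the assay and not a number.
Compound 2 `CCCCC[Se]c1nc([Se]CCCCC)c2ccccc2n1` gives > 100000 nM in this assay, again a limit.
Compound 3 `CCCCC[Se]c1nc(NCc2ccccc2)c2ccccc2n1` gives > 100000 nM in this assay, also a limit.

Compound 3 therefore stands at the same limit as the other two; no compound of the three can be placed above or below another on the numbers shown, because of the limit of > 100000 nM in this assay, at which 3 of the 3 values shown sit. The step recorded from compound 1 to compound 3 reads a step that the two limits leave unreadable from compound 1 to compound 3, and that from compound 2 to compound 3 reads a step that the two limits leave unreadable from compound 2 to compound 3; neither carries a readable size.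

Compound 4 `CCCCC[Se]c1nc(N)c2ccccc2n1` differs from compound 3 in one place: hydrogen in place of benzyl on a nitrogen on an aromatic ring. Going by the values given here, no measured step shows what loss of the benzyl group does to growth inhibition, and the steps that do exist are unreadable at both ends. The expectation for compound 4 can only follow compound 3: a result at the same limit, with the step from compound 3 to compound 4 in this assay expected as a number no higher from compound 3 to compound 4 (the limit leaves the size open). Compound 4 is accordingly estimated at 100000 nM, within a range from 30000 nM to 300000 nM, most likely reported again as a limit rather than a number.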

Compound 4, concentration for total growth inhibition: > 100000 nM
Compound 4: no number, only a limit; the forecaster's own chance of this, stated with the estimate: 85%; the middle value lies on the limit itself.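

In this assay compound 4 gives > 100000 nM, a limit of the assay and not a number. No new step can be read from compound 3 or compound 2 to compound 4: the limit of > 100000 nM in this assay, at which 4 of the 4 values shown sit.

The compounds shown leave open whether any change on the shared core yields a measurable number in this assay.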